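The source may report more compounds than this note shows. Statements on the series, on what has been measured and on what is new or still open speak of the compounds shown alone.

Measured in a functional assay on HCT-116 cells (Homo sapiens) for antiproliferative activity, read by MTT assay, with a stated time of 72 h; a higher number here means a weaker inhibitor, a lower number a stronger inhibitor:
Compound 1 `NC1=NC2(CCOCC2)N(OCCCOc2ccc(Cl)cc2)C(N)=N1`: 690 nM
Compound 2 `NC1=NC2(CCOCC2)N(OCCCOc2ccc(F)cc2)C(N)=N1`: 3280 nM
Compound 3 `NC1=NC2(CCOCC2)N(OCCCOc2ccc(Cl)cc2Cl)C(N)=N1`: 880 nM

Compound 3 lies within the scatter of compound 1, as shown by a 1.3-fold higher number from compound 1 to compound 3 (0.11 log units; within the scatter). That step is the addition of a second chloro group, and it leaves the number effectively unmoved. The one clear separation in the set involves the fluoro compound: a 4.8-fold higher number from compound 1 to compound 2 (0.68 log units; beyond the scatter) and a 3.7-fold lower number from compound 2 to compound 3 (0.57 log units; beyond the scatter), both modest.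

The next compound is compound 4 `NC1=NC2(CCOCC2)N(OCCCOc2cccc(Br)c2)C(N)=N1`, which has 3-bromophenyl in place of 2,4-dichlorophenyl on an oxygen on a saturated carbon. Among the measured compounds shown here, no measured compound carries bromo or the 3-bromophenyl group, so the steps above bear on this change only indirectly. The two chloro compounds give the nearest reference, while the fluoro step marks how far one halogen swap has moved the number. No step beyond the scatter is expected in this assay, and no direction is favoured: a 1.1-fold higher number from compound 3 to compound 4 (0.06 log units; within the scatter) is the expected step. For compound 4 the estimated value is 1000 nM, with an expected range of 400 nM to 3000 nM.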

Compound 4, half-maximal inhibitory concentration: 40 nM
Estimate against measurement, compound 4: 25-fold (1.40 log units) above; the measured number lies below the stated range.
By their numbers in this assay, from the lowest: compound 4; then compounds 1 and 3 (each within the scatter of the next); then compound 2.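

In this assay, the group on an oxygen on a saturated carbon proves a much stronger lever than the earlier halogen changes indicated, with 3-bromophenyl outperforming 2,4-dichlorophenyl (a 22-fold lower number from compound 3 to compound 4 (1.34 log units; beyond the scatter)), 4-chlorophenyl (a 17-fold lower number from compound 1 to compound 4 (1.24 log units; beyond the scatter)) and 4-fluorophenyl (an 82-fold lower number from compound 2 to compound 4 (1.91 log units; beyond the scatter)). Among the compounds shown here, compound 4 is therefore the strongest inhibitor of the four, and its steps exceed any seen among the earlier compounds. The change swaps both the halogen and its location on the aromatic ring, so the gain cannot be assigned to either alone, and nothing at hand explains it.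

On these data alone, whether bromo itself is required remains open. A methoxy group or a nitrile in place of the bromo would test this, and a longer chain carrying 3-bromophenyl would show whether the gain survives a change in the linker.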